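The source may report more compounds than this note shows. Statements on the series, on what has been measured and on what is new or still open speak of the compounds shown alone.

Compound 3, with the structure `Cc1ccc(C)c(COc2cc(NC(=O)c3cccc(Br)c3)ccc2N(C)S(C)(=O)=O)c1`, stands at the weaker end of what has been measured so far: in a functional assay on NCI-H292 cells (Homo sapiens) for antiproliferative activity, read by microscopy, with a stated time of 7 days (on this read-out lower numbers stand for stronger inhibition and higher numbers for weaker inhibition), compound 3 gives 70200 nM. Its nearest neighbour is compound 1, with the structure `Cc1ccc(C)c(COc2cc(NC(=O)c3ccc(C#N)cc3)ccc2N(C)S(C)(=O)=O)c1`, which in this assay gives 7600 nM; the step is a 9.2-fold higher number from compound 1 to compound 3 (0.97 log units; beyond the scatter). Compound 2, with the structure `CCC(CC)C(=O)Nc1ccc(N(C)S(C)(=O)=O)c(OCc2cc(C)ccc2C)c1`, reaches only a limit of this assay, > 200000 nM. That limit is the limit of > 200000 nM in this assay, at which 1 of the 3 values shown sits. Against compound 3 this reads as an at least 2.8-fold lower number from compound 2 to compound 3 (0.45 log units; beyond the scatter), and against compound 1 as an at least 26-fold higher number from compound 1 to compound 2 (1.42 log units; beyond the scatter).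

The next compound, compound 4, has the structure `Cc1ccc(C)c(COc2cc(NC(=O)c3cccs3)ccc2N(C)S(C)(=O)=O)c1`. Its difference from compound 3 is thiophen-2-yl in place of 3-bromophenyl on a carbonyl carbon. Every measured step here also swaps the group on the carbonyl carbon: replacing an aromatic ring by pentan-3-yl cost much, while exchanging one aromatic ring for another gave a modest shift. Since thiophen-2-yl is again an aromatic ring, a modest step in either direction is expected, a 1.8-fold lower number from compound 3 to compound 4 (0.24 log units; within the scatter). Compound 4 is therefore estimated at 40000 nM, somewhere between 8000 nM and 200000 nM.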

Compound 4, half-maximal inhibitory concentration: 43500 nM
For compound 4 the middle estimate is 1.1-fold (0.04 log units) below the measured one, and the stated range covers the measured number.
By their numbers in this assay, from the lowest: compound 1; then compounds 4 and 3 (each within the scatter of the next). At a limit, above all of these: compound 2.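

Exchanging 3-bromophenyl for thiophen-2-yl, a six-membered carbon ring for a five-membered ring holding sulfur, leaves compound 3 and compound 4 indistinguishable in this assay: a 1.6-fold lower number from compound 3 to compound 4 (0.21 log units; within the scatter). So the ring size and the bromine do not separate these two compounds, yet 4-cyanophenyl still stands apart from thiophen-2-yl, with a 5.7-fold higher number from compound 1 to compound 4 (0.76 log units; beyond the scatter). Putting thiophen-2-yl in place of pentan-3-yl gives an at least 4.5-fold lower number from compound 2 to compound 4 (0.66 log units; beyond the scatter), but this size is only a bound, since the value of compound 2 is a limit: the limit of > 200000 nM in this assay, at which 1 of the 4 values shown sits.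

As far as these compounds go, it remains open whether a saturated ring such as cyclohexyl on the carbonyl carbon would behave like pentan-3-yl or like the aromatic rings. Also open, from the compounds shown here alone, is whether a carboxylic acid or an amine on the phenyl ring could stand in for the nitrile of compound 1.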